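Methoxy in Place of Fluoro on a Weakly Active Core

The source may report more compounds than this note shows. Statements on the series, on what has been measured and on what is new or still open speak of the compounds shown alone.

Compound 3 `O=C1COc2ccc(F)cc2N1Cc1cn(Cc2ccccc2)nn1` carries a fluoro group on the shared core. In a functional assay on Hep 3B2 cells (Homo sapiens) for cytotoxicity, read by MTT assay, with a stated time of 6 days (on this read-out lower numbers stand for stronger inhibition and higher numbers for weaker inhibition), compound 3 gives > 100000 nM, which is a limit of the assay rather than a number. Compound 1 `Cc1ccc2c(c1)N(Cc1cn(Cc3ccccc3)nn1)C(=O)CO2`, the methyl analogue, likewise reaches only a limit in this assay, at > 100000 nM. Compound 2 `O=C1COc2ccc(Cl)cc2N1Cc1cn(Cc2ccccc2)nn1`, the chloro analogue, is the only one of the three with a measured number, giving 55500 nM in this assay. Among the measured steps, an at least 1.8-fold lower number from compound 1 to compound 2 (0.25 log units; that floor lies within the scatter) and an at least 1.8-fold higher number from compound 2 to compound 3 (0.25 log units; that floor lies within the scatter) each sit at a floor within the scatter, and a step that the two limits leave unreadable from compound 1 to compound 3. None of these steps brings in a methoxy group. Compound 4 `COc1ccc2c(c1)N(Cc1cn(Cc3ccccc3)nn1)C(=O)CO2` differs from compound 3 by methoxy in place of fluoro on an aromatic carbon. With the two readable steps giving nothing beyond the scatter, and two of the three values sitting at the limit of > 100000 nM in this assay, at which 2 of the 3 values shown sit, no step beyond the scatter is expected in this assay. Compound 4 is therefore estimated at 100000 nM, within a range of 40000 nM to 300000 nM, which would mean a number no higher from compound 3 to compound 4 (the limit leaves the size open).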

Compound 4, half-maximal inhibitory concentration: > 100000 nM
Compound 4 was reported as a limit; the forecaster's own chance of this, stated with the estimate: 60%; the middle value lies on the limit itself.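

Compound 4 gives > 100000 nM in this assay, which is a limit of the assay and not a number. Methoxy in place of chloro gives an at least 1.8-fold higher number from compound 2 to compound 4 (0.25 log units; that floor lies within the scatter), a floor that does not separate the two substituents, and the steps from compound 1 and compound 3 to compound 4 cannot be read. Methoxy brings a hydrogen-bond acceptor to this position, which the fluoro group of compound 3 does not, yet the result is still no measured number, and compound 2 remains the only one of the series with one: the limit of > 100000 nM in this assay, at which 3 of the 4 values shown sit.

On these data alone, how compound 1, compound 3 and compound 4 rank among themselves stays open, as all three sit at the limit. Also open, as far as these compounds go, is whether an amine or a carboxylic acid at this position would give a measured number in this assay.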